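The source may hold more compounds than are shown below. What is called first, only, known or untested is meant among the compounds shown, and "the series" means these compounds.

Measured in a functional assay on A549 cells (Homo sapiens) for cytotoxicity, read by resazurin assay, with a stated time of 48 h; a lower number here means a stronger inhibitor, a higher number a weaker inhibitor:
- Compound 1 `C=C(C)[C@@H]1CC=C(CN(OC)C2O[C@@H](CO)[C@H](N=[N+]=[N-])[C@@H](O)[C@@H]2O)CC1`: 451000 nM
- Compound 2 `C=C(C)[C@@H]1CC=C(CN(OC)C2O[C@H](CN=[N+]=[N-])[C@@H](N=[N+]=[N-])[C@H](O)[C@H]2O)CC1`: 44000 nM
- Compound 3 `C=C(C)[C@@H]1CC=C(CN(OC)C2OC[C@@H](O)[C@H](O)[C@H]2O)CC1`: 202000 nM

Compound 3 holds the second highest of these three numbers. Compound 1 stands higher and compound 2 lower, both beyond the scatter. Compound 4 `C=C(C)[C@@H]1CC=C(CN(OC)C2O[C@H](CN=[N+]=[N-])[C@@H](O)[C@H](O)[C@H]2O)CC1` differs from compound 3 by azidomethyl in place of hydrogen on a saturated ring carbon, next to the ring oxygen. Among the measured compounds shown here, no measured pair isolates this change. For the measured compounds named here, compound 2, the only measured compound bearing azidomethyl, gives the lowest number, 44000 nM, so a moderate step toward a lower number is expected. The estimated step is a 2.2-fold lower number from compound 3 to compound 4 (0.35 log units; beyond the scatter). For compound 4 the expected value is 90000 nM, with an estimated range of 30000 nM to 270000 nM.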

Compound 4, half-maximal inhibitory concentration: 163000 nM
For compound 4 the middle estimate is 1.8-fold (0.26 log units) below the measured one, within the range that was stated.
By their numbers in this assay, from the lowest: compound 2; then compounds 4 and 3 (each within the scatter of the next); then compound 1.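

In this assay, azidomethyl in place of hydrogen on a saturated ring carbon, next to the ring oxygen, gives a 1.2-fold lower number from compound 3 to compound 4 (0.09 log units; within the scatter), so adding this group leaves the number within the scatter. With azidomethyl kept, hydroxy in place of azido on a saturated ring carbon gives a 3.7-fold higher number from compound 2 to compound 4 (0.57 log units; beyond the scatter), so it is this exchange that produces a step beyond the scatter. Nothing available explains either step. 

The compounds shown leave open whether an amine or a longer chain in place of azidomethyl would shift the number. They also leave open whether an amine in place of the ring azido group would do so.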